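Trimming the Amide: From Benzamido to Acetamido

The source may report more compounds than this note shows. Statements on the series, on what has been measured and on what is new or still open speak of the compounds shown alone.

Two compounds share one core and differ only in the group on a saturated ring carbon of the side chain. Compound 1 `O=C(OC1CCC(CN2CCN(c3cc(=O)c4cc(C(F)(F)F)cc([N+](=O)[O-])c4s3)CC2)CC1)C1CCC1` carries a (cyclobutylcarbonyl)oxy group there. In an ADME assay on Vero cells (Chlorocebus sabaeus) for cytotoxicity, read by MTT assay, with a stated time of 48 h (a higher number here means a weaker inhibitor, a lower number a stronger inhibitor), compound 1 reaches only a limit, > 64 ug/mL, so no number is known for it. Among the compounds with values here, compound 2 `O=C(NC1CCC(CN2CCN(c3cc(=O)c4cc(C(F)(F)F)cc([N+](=O)[O-])c4s3)CC2)CC1)c1ccccc1` carries benzamido in place of (cyclobutylcarbonyl)oxy, and in this assay compound 2 gives 44.3 ug/mL, the only plain number so far. The step of an at least 1.4-fold lower number from compound 1 to compound 2 (0.15 log units; that floor lies within the scatter) has only a floor. That floor follows from the limit of > 64 ug/mL in this assay, at which 1 of the 2 values shown sits, where compound 1 sits.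

Compound 3 `CC(=O)NC1CCC(CN2CCN(c3cc(=O)c4cc(C(F)(F)F)cc([N+](=O)[O-])c4s3)CC2)CC1` is the next member. It differs from compound 2 by methyl in place of phenyl on a carbonyl carbon. Within the data shown here, the one measured step sits within the scatter and touched a different part of the side chain than the carbonyl carbon changed here, so no measured step bears on it directly. A step within the scatter is therefore expected, a 1.1-fold higher number from compound 2 to compound 3 (0.05 log units; within the scatter). For compound 3 in this assay the estimate is 50 ug/mL, expected to lie between 25 ug/mL and 100 ug/mL.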

Compound 3, half-maximal inhibitory concentration: > 64 ug/mL
Compound 3 ended at the assay's limit; the forecaster's own chance of this, stated with the estimate: 35%; middle value at least 1.2-fold (0.10 log units) away from the limit.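

Replacing phenyl with methyl on a carbonyl carbon turns benzamido into acetamido and gives, in this assay, an at least 1.4-fold higher number from compound 2 to compound 3 (0.15 log units; that floor lies within the scatter). Compound 3 gives > 64 ug/mL, a limit and not a number, and the step keeps only a floor because of where that reading sits: the limit of > 64 ug/mL in this assay, at which 2 of the 3 values shown sit. What is new at this position is that an amide on the saturated ring carbon does not by itself bring a plain number: compound 3 carries an amide just as compound 2 does, yet of the three compounds only compound 2, with its benzamido group, has one.

The step between compound 1 and compound 3 cannot be read, since both stop at a limit, and the floor from compound 2 to compound 3 is too small to show that the two truly differ. Also open, going by these compounds, is whether a longer chain on the carbonyl carbon, such as propionamido, or a free amine on the same saturated ring carbon would give a plain number in this assay.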